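The source may hold more compounds than are shown below. What is called first, only, known or untested is meant among the compounds shown, and "the series" means these compounds.

Measured compounds:
- Compound 1, `Cc1cc(C)c(CN2CCc3c(F)cc(O[C@@H]4CCOC4)c(Cl)c3C2=O)c(=O)[nH]1`: compound 1 gives 260 nM in an assay on Sf9 cells for inhibition of histone-lysine N-methyltransferase EZH2 variant Y641N (Homo sapiens), read by scintillation counting, with a stated time of 60 min, in the presence of a further agent that is not named here; a higher number here means a weaker inhibitor, a lower number a stronger inhibitor
- Compound 2, `Cc1cc(C)c(CN2CCc3c(Cl)cc(-c4cn[nH]c4C)c(Cl)c3C2=O)c(=O)[nH]1`: compound 2 gives 110 nM in this assay
- Compound 3, `Cc1cc(C)c(CN2CCc3c(Cl)cc(-c4cn[nH]c4)c(Cl)c3C2=O)c(=O)[nH]1`: compound 3 gives 270 nM in this assay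

Compound 1 stands second highest of the three numbers in this assay. Its value and that of compound 3 lie within the scatter of each other, so nothing separates them; against compound 2 its number is higher, and that gap lies beyond the scatter.

Compound 4, `Cc1cc(C)c(CN2CCc3ccc(O[C@@H]4CCOC4)c(Cl)c3C2=O)c(=O)[nH]1`, has not yet been measured. It differs from compound 1 in one place: hydrogen in place of fluoro on an aromatic carbon.

Among the measured compounds shown here, only one step between measured compounds is available, and it concerns a different change at a different place: a 2.5-fold higher number from compound 2 to compound 3 (0.39 log units; beyond the scatter). For the measured compounds named here, no measured pair isolates the removal of a fluoro from the shared core, so the step from compound 1 to compound 4 has no direct precedent here. Going by the values given here, the one known step was modest in size, which suggests that single small changes on this scaffold move the number only moderately. On that basis compound 4 is expected to fall near compound 1, with a slight lean toward a higher number, an expected step of a 1.5-fold higher number from compound 1 to compound 4 (0.19 log units; within the scatter). The estimate for compound 4 in this assay is 400 nM, with a range from 150 nM to 1000 nM.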

Compound 4, half-maximal inhibitory concentration in the histone-lysine N-methyltransferase EZH2 assay: 110 nM
Beside the measured number, compound 4's estimate is 3.6-fold (0.56 log units) above it; the whole stated range lies above it.
By their numbers in the histone-lysine N-methyltransferase EZH2 assay, from the lowest: compounds 2 and 4 (each within the scatter of the next); then compounds 1 and 3 (each within the scatter of the next).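

In the histone-lysine N-methyltransferase EZH2 assay, hydrogen in place of fluoro on this aromatic carbon gives a 2.4-fold lower number from compound 1 to compound 4 (0.37 log units; beyond the scatter), so inhibition does not depend on the fluoro at this place in the presence of the (oxolan-3-yl)oxy group. Among the compounds shown here, the earlier compounds could not show this, since their only step lay at another place on the shared core and left this carbon untouched. In a physicochemical assay for lipophilicity, at pH 7.4 (a lower number here means a more polar compound, a higher number a more lipophilic compound), compound 1 gives 2.1 and compound 4 gives 1.5, so the stronger inhibitor of this pair is also the more polar compound, and the gain in inhibition does not come with added lipophilicity: the measured distribution coefficient of compound 1, 2.1, and of compound 4, 1.5, a number 0.60 log units lower (beyond the scatter)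

The compounds shown leave open whether a group other than hydrogen or fluoro on this aromatic carbon, such as a methoxy group, a nitrile or an amine, would move either number further. They also do not tell whether hydrogen on this carbon would give a similar step in compound 2 or compound 3, which carry a chloro there and a different group in place of the (oxolan-3-yl)oxy group.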